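Cytotoxicity Estimate for an Amino Acid Side Chain Variant

A few compounds are considered here, and "the series" means these few. Any claim that something is new, unique, unknown or untested is made for them only; others in the source may bear on it.

Measured compounds:
compound 1 `COc1cc2c(cc1O)CCC(C)(CC(N)=O)O2`: 100%
compound 2 `COc1cc2c(cc1O)CCC(C)(CCNC(C)=O)O2`: 90.7%

In an ADME assay on SH-SY5Y cells (Homo sapiens) for cytotoxicity, read by MTT assay, with a stated time of 24 h, tested at 3.1 uM (a higher number here means a weaker effect of the compound at the concentration tested, a lower number a stronger effect), compound 1 gives 100%, and compound 2 gives 90.7%. Of the two numbers shown, that of compound 2 is the smaller, yet the only step between them, a number 9.3 percentage points lower from compound 1 to compound 2 (within the scatter), lies within the scatter, so the two compounds are not told apart.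

Compound 3 `COc1cc2c(cc1O)CCC(C)(CC(N)C(=O)O)O2` is the next variant of the same core. Its change from compound 2 is amino(carboxy)methyl in place of acetamidomethyl on a saturated chain carbon bound to a saturated ring carbon. Going by the values given here, the one measured step that bears on it is the earlier change at the same place, a number 9.3 percentage points lower from compound 1 to compound 2 (within the scatter), which stayed within the scatter. Nothing in the measured pair points to a step beyond the scatter in this assay in either direction.

Compound 3 is therefore expected to give 95%, in a range from 80% to 105%. That estimate means a number 4.3 percentage points higher from compound 2 to compound 3 (within the scatter), which is expected to remain within the scatter.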

Compound 3, a percentage reported as activity, at one concentration (the size of the read-out at that concentration, not a potency): 100%
Compound 3: middle estimate off by 5 percentage points, on the low side; low and high end bracket the measured number.
By their numbers in this assay, from the lowest: compounds 2, 1 and 3 (each within the scatter of the next).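

In this assay, putting amino(carboxy)methyl in place of acetamidomethyl on a saturated chain carbon bound to a saturated ring carbon gives a number 9.3 percentage points higher from compound 2 to compound 3 (within the scatter) and putting it in place of carbamoyl gives no change at the digits printed from compound 1 to compound 3 (within the scatter) in the same read-out. This place has now carried three different groups, one of them holding both an amine and a carboxylic acid, and at this single concentration the three compounds are not told apart. Nothing available explains why these groups cannot be told apart here.

The compounds shown leave open whether a longer chain, a carboxylic acid without the amine, or a phenyl group at this place would stand apart from these three in this assay at all. They also leave open whether the three would remain together at other concentrations.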